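A few compounds are considered here, and "the series" means these few. Any claim that something is new, unique, unknown or untested is made for them only; others in the source may bear on it.

Compound 1 `COc1cc(F)ccc1Nc1nn(C2CCCCO2)c2cc(-c3c(C)noc3C)ccc12`: 8500 nM
Compound 2 `Cc1ccc(Cn2nc(Nc3ccc(F)cc3)c3ccc(-c4c(C)noc4C)cc32)cc1`: "not determined" (no result reported)

Only compound 1 has a number in a functional assay on MV4-11 cells (Homo sapiens) for antiproliferative activity, read by luminescence and CellTiter-Glo, with a stated time of 72 h (a lower number here means a stronger inhibitor, a higher number a weaker inhibitor), where compound 1 gives 8500 nM. Compound 2 has no single number there, and its entry reads "not determined" (no result reported). Compound 3 `COc1ccc(Nc2nn(Cc3ccc(C)cc3)c3cc(-c4c(C)noc4C)ccc23)cc1` has yet to be measured in this assay. The structural change is methoxy in place of fluoro on an aromatic carbon, para to a large group, which can also be read as 4-fluorophenyl to 4-methoxyphenyl. Among the compounds with values here, no measured pair shows what this replacement does, so no step beyond the usual scatter is expected in this assay, in either direction. Within the data shown here, the only number available as a guide is that of compound 1 at 8500 nM, so the expected range stays wide. Compound 3 is estimated at 3000 nM, with an expected range of 300 nM to 20000 nM.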

Compound 3, half-maximal inhibitory concentration: 11900 nM
Compound 3: middle estimate off by 4.0-fold (0.60 log units), on the low side; measured number inside the range.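

Within the data shown here, compound 2 has no single number in this assay, and no step from it to compound 3 can be read. The compounds shown leave open what 4-methoxyphenyl in place of 4-fluorophenyl does to antiproliferative activity. Nothing at hand speaks to an explanation for the value of compound 3.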